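Replacing the carboxy group of compound 1 with an aryl amine

The source may hold more compounds than are shown below. What is called first, only, known or untested is meant among the compounds shown, and "the series" means these compounds.

Compound 1 `O=C(O)CCC(=O)OCCCCCCSc1ccc([N+](=O)[O-])c2nonc12`: 8740 nM
Compound 2 `COc1ccc(NC(=O)CCC(=O)OCCCCCCSc2ccc([N+](=O)[O-])c3nonc23)cc1`: 1800 nM

Both numbers come from a functional assay on HOS cells (Homo sapiens) for inhibition, read by MTT assay, with a stated time of 72 h; a higher number here means a weaker inhibitor, a lower number a stronger inhibitor. Compound 1 has the highest of the two numbers, so it is the weaker inhibitor of the pair. For the measured compounds named here, the one step measured so far is a 4.9-fold lower number from compound 1 to compound 2 (0.69 log units; beyond the scatter), a modest drop. Compound 3 `O=C(CCC(=O)OCCCCCCSc1ccc([N+](=O)[O-])c2nonc12)Nc1ccc(F)c(Cl)c1` has not yet been measured; it differs from compound 1 in one place: (3-chloro-4-fluorophenyl)amino in place of hydroxy on a carbonyl carbon. This is the same kind of change at the same carbonyl carbon as the measured step, so a drop of similar size is expected, a 5.5-fold lower number from compound 1 to compound 3 (0.74 log units; beyond the scatter). Compound 3 is therefore estimated at 1600 nM, within a range from 500 nM to 5000 nM.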

Compound 3, half-maximal inhibitory concentration: 2800 nM
Beside the measured number, compound 3's estimate is 1.8-fold (0.24 log units) below it; the measured number falls inside the stated range.
By their numbers in this assay, from the lowest: compounds 2 and 3 (each within the scatter of the next); then compound 1.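

Putting a second aryl amine in place of the hydroxy gives a 3.1-fold lower number from compound 1 to compound 3 (0.49 log units; beyond the scatter) and shows that the lower number of compound 2 is not tied to a single aryl group. The two aryl groups cannot be told apart here: 3-chloro-4-fluorophenyl in place of 4-methoxyphenyl on the amide-type nitrogen gives a 1.6-fold higher number from compound 2 to compound 3 (0.19 log units; within the scatter) and no order between them can be read. No evidence is available to explain either step.

From the compounds shown here alone, whether an aromatic ring is needed at all stays open. A cyclohexylamine or a plain methylamine on the same carbonyl carbon would address that.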